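This account rests on a few compounds, and the source may have more. Where it says the series, first, only, none or still open, it means among the compounds named here.

Going by the values given here, compound 3, `CCCCCCCCCCCCCCNC(=O)[C@H](CO)/N=C/c1cccc(O)c1`, is one of three compounds measured in a functional assay on cells (Homo sapiens) for cytotoxicity, read by MTT assay, with a stated time of 24 h; on this read-out higher numbers stand for weaker inhibition and lower numbers for stronger inhibition. In this assay compound 3 gives 32600 nM. Its closest neighbour on this read-out is compound 1, `CCCCCCCCCCCCCCNC(=O)[C@H](CO)NCc1ccccc1[N+](=O)[O-]`, which in this assay gives 29400 nM; the third compound, compound 2, `CCCCCCCCCCCCCCNC(=O)[C@H](CO)/N=C/c1ccccc1O`, gives 19000 nM. Among the compounds with values here, the only single-point step measured so far runs from compound 2 to compound 3, where a 1.7-fold higher number from compound 2 to compound 3 (0.23 log units; within the scatter), so the three numbers are not separated from one another beyond the usual scatter.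

Compound 4 is `CCCCCCCCCCCCCCNC(=O)[C@H](CO)NCc1ccccc1O`. It differs from compound 3 in one place: a group of 9 heavy atoms (7 carbon, 1 nitrogen, 1 oxygen; one six-membered aromatic ring of carbon only) in place of a group of 9 heavy atoms (7 carbon, 1 nitrogen, 1 oxygen; one six-membered aromatic ring of carbon only), on a saturated chain carbon bound to a carbonyl carbon and a saturated chain carbon. Within the data shown here, no measured step matches this change directly. Compound 4 and compound 2 both carry the hydroxyl at the 2-position, and compound 1 shows that a benzylamino group alongside an imine-bearing compound gives numbers within the scatter of each other. Compound 4 is therefore expected to sit close to compound 2, with a 1.5-fold lower number from compound 3 to compound 4 (0.17 log units; within the scatter), a step within the scatter. Compound 4 is estimated at 22000 nM, in a range from 11000 nM to 45000 nM.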

Compound 4, half-maximal inhibitory concentration: 75300 nM
For compound 4 the middle estimate is 3.4-fold (0.53 log units) below the measured one, outside the stated range (above it).
By their numbers in this assay, from the lowest: compounds 2, 1 and 3 (each within the scatter of the next); then compound 4.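

In this assay, going by these compounds alone, the (2-hydroxybenzyl)amino group gives the first steps beyond the scatter at this saturated chain carbon, with a 2.3-fold higher number from compound 3 to compound 4 (0.36 log units; beyond the scatter) and a 4.0-fold higher number from compound 2 to compound 4 (0.60 log units; beyond the scatter), so the activity is weaker in both comparisons. Compound 2 also carries a hydroxyl at the 2-position of its ring, so the second step shows that the double bond to nitrogen can count even when that hydroxyl stays in place. With the saturated link kept, hydroxy in place of nitro on an aromatic carbon also counts, giving a 2.6-fold higher number from compound 1 to compound 4 (0.41 log units; beyond the scatter).

No available measurement explains these steps. As far as these compounds go, a methoxy group or an amine in place of the hydroxyl remains open, as does a (3-hydroxybenzyl)amino group at this position.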